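Butyl sulfonate cinnamate series: ester chain extension note

The source may hold more compounds than are shown below. What is called first, only, known or untested is meant among the compounds shown, and "the series" means these compounds.

Measured so far in a toxicity assay on L02 cells (Homo sapiens) for cytotoxicity, read by MTT assay, with a stated time of 24 h; on this read-out higher numbers stand for lower toxicity in this test and lower numbers for higher toxicity in this test:
- compound 1 `CCCCS(=O)(=O)Oc1ccc(/C=C/C(=O)OCC)cc1OC`: 14400 nM
- compound 2 `COc1cc(/C=C/C(=O)Nc2cccc(C)c2)ccc1OS(=O)(=O)c1ccc(Cl)cc1`: 73500 nM
- compound 3 `COc1cc(/C=C/C(=O)Nc2ccc(I)cc2)ccc1OS(=O)(=O)c1ccc(Cl)cc1`: 39400 nM

Compound 1 gives the lowest number of the three, and its gaps to compound 3 and to compound 2 both lie beyond the scatter; compounds 2 and 3, which carry an amide in place of the ester of compound 1 and an aryl sulfonate in place of its alkyl sulfonate, sit together, as the step of a 1.9-fold lower number from compound 2 to compound 3 (0.27 log units; within the scatter) lies within the scatter.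

The unmeasured compound 4 `CCCCOC(=O)/C=C/c1ccc(OS(=O)(=O)CCCC)c(OC)c1` is reached from compound 1 by one change: ethyl in place of hydrogen on a saturated chain carbon, two bonds along the chain from an oxygen next to a carbonyl group. Among the compounds with values here, the only measured step, a 1.9-fold lower number from compound 2 to compound 3 (0.27 log units; within the scatter), concerns the amide-type nitrogen of an unrelated pair and gives no guidance on extending the chain of the ester of compound 1. Within the data shown here, no measured pair bears on this change, so no step beyond the scatter is expected in this assay in either direction.

Compound 4 is therefore expected to give 14000 nM. The range for compound 4 is estimated from 5000 nM to 40000 nM. The step of a 1.0-fold lower number from compound 1 to compound 4 (0.01 log units; within the scatter) is expected to stay within the scatter of repeated measurements.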

Compound 4, half-maximal cytotoxic concentration: 115000 nM
Compound 4: the middle estimate sits 8.2-fold (0.91 log units) below what was measured; measured number outside the range, above it.
By their numbers in this assay, from the lowest: compound 1; then compounds 3, 2 and 4 (each within the scatter of the next, the first and the last beyond it).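

The ester position is not silent in this assay: with the butyl sulfonate and the rest of the core of compound 1 unchanged, going from ethoxy to butoxy gives an 8.0-fold higher number from compound 1 to compound 4 (0.90 log units; beyond the scatter) and moves the number towards lower toxicity in this test. Of the steps between compounds differing in one place, this is the first beyond the scatter, whereas the earlier step concerned the amide-type nitrogen and stayed within it, so the ester chain is the first place in the series shown to change the number on its own. No supporting data accompany this result that could account for the step.

Going by these compounds, this rests on a single pair, so it remains open whether the number keeps rising with a longer chain such as hexyl, levels off or falls back, and where a propyl ester would fall. Also open, on these data alone, is whether a carboxylic acid in place of the ester moves the number, and whether the same chain extension gives a similar step when an aryl sulfonate replaces the butyl sulfonate.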